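The source may report more compounds than this note shows. Statements on the series, on what has been measured and on what is new or still open speak of the compounds shown alone.

Compound 2 `O=C(O)c1ccc(-c2cnc(C(=O)CCc3ccc(-c4ccccc4)cc3)o2)nc1` is the weaker of the two compounds measured in an assay for inhibition of Fatty-acid amide hydrolase 1 (Rattus norvegicus); a lower number here means a stronger inhibitor, a higher number a weaker inhibitor: compound 2 gives 14 nM, whereas compound 1 `O=C(CCc1ccc(-c2ccccc2)cc1)c1ncc(-c2ccncc2)o1` gives 2.3 nM. Going by the values given here, the only step recorded between them, a 6.1-fold higher number from compound 1 to compound 2 (0.78 log units; beyond the scatter), came from putting 5-carboxypyridin-2-yl in place of pyridin-4-yl on an aromatic carbon of the shared core.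

Compound 3 `CN(C)C(=O)c1cnc(C(=O)CCc2ccc(-c3ccccc3)cc2)o1` differs from compound 2 by dimethylcarbamoyl in place of 5-carboxypyridin-2-yl on an aromatic carbon, the replacement sitting on an aromatic carbon of the five-membered aromatic ring with one nitrogen and one oxygen, next to the ring oxygen. Among the compounds with values here, no measured step covers the loss of the carboxypyridinyl ring in favour of a dimethylcarbamoyl group, so the one recorded step, a 6.1-fold higher number from compound 1 to compound 2 (0.78 log units; beyond the scatter), bears on it only loosely: it shows that this position tolerates a change of group with a modest shift in this assay. The step is therefore expected to be modest, and its direction is uncertain, so a 1.4-fold higher number from compound 2 to compound 3 (0.15 log units; within the scatter) is the estimate for compound 3. Compound 3 is expected to give about 20 nM, within a range from 5 nM to 80 nM.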

Compound 3, inhibition constant: 3 nM
Compound 3: the middle estimate sits 6.7-fold (0.82 log units) above what was measured, and the stated range ends above it.
By their numbers in this assay, from the lowest: compounds 1 and 3 (each within the scatter of the next); then compound 2.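

In this assay, the carbon next to the ring oxygen does not need an aromatic ring to keep a low number: dimethylcarbamoyl in place of 5-carboxypyridin-2-yl gives a 4.7-fold lower number from compound 2 to compound 3 (0.67 log units; beyond the scatter), while dimethylcarbamoyl in place of pyridin-4-yl gives a 1.3-fold higher number from compound 1 to compound 3 (0.12 log units; within the scatter). The earlier compounds shown here both carried a six-membered aromatic ring here, whereas compound 3 has no ring at this carbon and still cannot be told apart from compound 1, so of the three groups seen at this place only 5-carboxypyridin-2-yl stands apart, with the higher number. Nothing measured here accounts for the separation of compound 2 from the other two.

The compounds shown leave open whether this result is particular to dimethylcarbamoyl or also holds for a primary carboxamide, a methyl ester or a morpholine amide at this carbon. They also leave open whether a carboxylic acid attached directly to this carbon, without the six-membered aromatic ring, would give a number closer to that of compound 2 or that of compound 3.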